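Demethylation step in a benzimidazole-like fused series: cytotoxicity notes

This account rests on a few compounds, and the source may have more. Where it says the series, first, only, none or still open, it means among the compounds named here.

Measured values:
- compound 1 `Cn1c(-c2ccc([N+](=O)[O-])cc2)nc2cc(C(F)(F)F)ccc21`: > 100000 nM
- compound 2 `O=[N+]([O-])c1ccc(-c2nc3cc(C(F)(F)F)ccc3[nH]2)cc1`: 18000 nM
- compound 3 `Cn1c(-c2ccc(NC(=O)CN3CCCCC3)cc2)nc2cc(C(F)(F)F)ccc21`: > 100000 nM

In an ADME assay on BHK cells (Mesocricetus auratus) for cytotoxicity, read by MTT assay, with a stated time of 96 h (on this read-out lower numbers stand for higher toxicity in this test and higher numbers for lower toxicity in this test), compound 1 gives > 100000 nM, which is a limit of the assay and not a number. Compound 2 in this assay gives 18000 nM. The change between them is hydrogen in place of methyl on an aromatic nitrogen, and the step is an at least 5.5-fold lower number from compound 1 to compound 2 (0.74 log units; beyond the scatter).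

Compound 3 differs from compound 1 by (((piperidin-1-yl)methyl)carbonyl)amino in place of nitro on an aromatic carbon. In this assay compound 3 gives > 100000 nM, again a limit. The step that the two limits leave unreadable from compound 1 to compound 3 cannot be read because of the limit of > 100000 nM in this assay, at which 2 of the 3 values shown sit.

Compound 4 `O=C(CN1CCCCC1)Nc1ccc(-c2nc3cc(C(F)(F)F)ccc3[nH]2)cc1` is not yet measured. It differs from compound 3 by hydrogen in place of methyl on an aromatic nitrogen. The places differ in wording: compound 1 to compound 2 sits next to a ring atom bearing a group of 9 heavy atoms, compound 3 to compound 4 next to one bearing a large group, so this is the same kind of change, not the same. In this assay the step of an at least 2.5-fold lower number from compound 3 to compound 4 (0.39 log units; beyond the scatter) is expected, resting on an at least 5.5-fold lower number from compound 1 to compound 2 (0.74 log units; beyond the scatter). Compound 4 is estimated at 40000 nM, between 12000 nM and 150000 nM.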

Compound 4, half-maximal cytotoxic concentration: 12000 nM
For compound 4 the middle estimate is 3.3-fold (0.52 log units) above the measured one; low and high end bracket the measured number.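

In this assay, hydrogen in place of methyl on the aromatic nitrogen again gives a lower number on the second core, with an at least 8.3-fold lower number from compound 3 to compound 4 (0.92 log units; beyond the scatter). From the compounds shown here alone, the direction therefore carries over between these two cores, but the comparison of sizes remains open: the same change on two cores in this assay, an at least 5.5-fold lower number (0.74 log units; beyond the scatter) from compound 1 to compound 2 and an at least 8.3-fold lower number (0.92 log units; beyond the scatter) from compound 3 to compound 4; the limit leaves it open whether they differ. The starting values of compound 1 and compound 3 are limits of the assay and not numbers, so neither step has a fixed size: the limit of > 100000 nM in this assay, at which 2 of the 4 values shown sit.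

Going by these compounds, whether the same direction holds with an ethyl group or a longer chain on that nitrogen remains open. So does its behaviour on a core carrying an amine or a carboxylic acid in place of nitro or (((piperidin-1-yl)methyl)carbonyl)amino.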